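Swapping isopropyl for methoxy on an acid amidase inhibitor

The source may report more compounds than this note shows. Statements on the series, on what has been measured and on what is new or still open speak of the compounds shown alone.

Of the compounds shown here, three have been tested in an assay on isolated protein for inhibition of N-acylethanolamine-hydrolyzing acid amidase (Homo sapiens), read by fluorescence, with a stated time of 90 min; on this read-out higher numbers stand for weaker inhibition and lower numbers for stronger inhibition. Compound 1 `COc1ccc(-c2cnc(C(=O)N[C@H]3C[C@@H](N=C=S)C3)cn2)cc1` gives 853 nM in this assay. Compound 3 `COc1ccc(-c2ccc(C(=O)N[C@]34C[C@](N=C=S)(C3)C4)c(F)c2)cc1` gives 1230 nM. Compound 2 `CC(C)c1ccc(-c2ccc(CO[C@H]3C[C@@H](N=C=S)C3)c(F)c2)cc1F` gives 227 nM, the lowest of the three numbers; the gaps to compound 1 and to compound 3 both lie beyond the usual scatter, so compound 2 is the strongest inhibitor measured here.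

Compound 4 `COc1ccc(-c2ccc(CO[C@H]3C[C@@H](N=C=S)C3)c(F)c2)cc1F` has not been measured. It differs from compound 2 in one place: methoxy in place of isopropyl on an aromatic carbon. Among the measured compounds shown here, compound 1 and compound 3 also carry a methoxy group on their outer ring, but they differ from compound 2 in other parts as well, so no single measured pair isolates this change.

With no direct comparison available, the step from compound 2 to compound 4 is expected to be a modest increase in this assay, around the edge of the scatter, with an estimated size of a 2.2-fold higher number from compound 2 to compound 4 (0.34 log units; beyond the scatter). Compound 4 is therefore expected to give about 500 nM in this assay, with a range from 150 nM to 1700 nM.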

Compound 4, half-maximal inhibitory concentration: 20.6 nM
Estimate against measurement, compound 4: 24-fold (1.39 log units) above, outside the stated range (below it).
By their numbers in this assay, from the lowest: compound 4; then compound 2; then compounds 1 and 3 (each within the scatter of the next).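

At this position on the outer ring, ortho to a fluoro group and para to a large group, methoxy in place of isopropyl gives an 11-fold lower number from compound 2 to compound 4 (1.04 log units; beyond the scatter) in this assay. Among the compounds shown here, compound 1 and compound 3 also carry a methoxy group, but they differ from compound 2 in other places as well, so only this pair ties a change in the number to the group alone, and it shows that the choice of group at this position can matter greatly. The swap replaces an all-carbon group with one containing oxygen and a hydrogen-bond acceptor, but nothing shown here explains why the step is so large.

From the compounds shown here alone, with only isopropyl and methoxy compared at this position, it remains open how an ethoxy group, a hydroxyl group or a dimethylamino group would behave there. Going by these compounds, it is also open whether isopropyl in place of methoxy would produce a similar step on the amide-linked cores of compound 1 and compound 3.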